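Amino for chloro on the shared core: cytotoxicity notes

The compounds below may be only part of what the source reports. "The series", "measured", "known", "first", "only" and "open" are said of these compounds alone.

Of the compounds shown here, three have been measured in a functional assay on DU-145 cells (Homo sapiens) for cytotoxicity, read by sulforhodamine B assay, with a stated time of 48 h; on this read-out higher numbers stand for lower toxicity in this test and lower numbers for higher toxicity in this test. Compound 1 `ClCc1ccccc1Cn1cnc2c(Cl)nc(Cl)nc21` gives 6310 nM, the lowest number of the three and hence the highest toxicity in this set, with both other compounds beyond the scatter from it. Compound 3 `ClCc1ccccc1Cn1cnc2ncnc(Cl)c21` gives 33100 nM, the nearer of the two, and compound 2 `Nc1nc(Cl)c2ncn(Cc3ccc(CCl)cc3)c2n1` gives 43700 nM, the furthest. Compound 4 `Nc1nc(Cl)c2ncn(Cc3ccccc3CCl)c2n1` is not yet measured; it differs from compound 1 by amino in place of chloro on an aromatic carbon. Going by the values given here, no measured pair isolates this exchange, so its size rests on expectation. Compound 2 carries the same amino group and gives 43700 nM, which points toward a higher number. The expected step is a 4.8-fold higher number from compound 1 to compound 4 (0.68 log units; beyond the scatter), a loss of toxicity beyond the scatter. Compound 4 is estimated at 30000 nM, within 10000 nM to 100000 nM.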

Compound 4, concentration lethal to 50% of the cells: 70800 nM
Compound 4: the middle estimate sits 2.4-fold (0.37 log units) below what was measured; the range from low to high includes it.
By their numbers in this assay, from the lowest: compound 1; then compounds 3, 2 and 4 (each within the scatter of the next, the first and the last beyond it).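

In this assay, going by these compounds alone, amino in place of chloro on the aromatic carbon between two ring nitrogen atoms gives an 11-fold higher number from compound 1 to compound 4 (1.05 log units; beyond the scatter), the first direct reading of this exchange on the shared core. The position is therefore sensitive to this change, and the loss of toxicity is large. No supporting data on the origin of this step are available.

Within the data shown here, only this one exchange has been read at this position. On these data alone, whether a methoxy or dimethylamino group would give a similar number remains open.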